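This account rests on a few compounds, and the source may have more. Where it says the series, first, only, none or still open, it means among the compounds named here.

Measured compounds:
- compound 1, `COc1ccc(S(N)(=O)=O)cc1C(=O)Nc1cccc(-c2nncn2C(C)C)n1`: 13%
- compound 2, `COc1cc(C)c(S(N)(=O)=O)cc1C(=O)Nc1cccc(-c2nncn2C(C)C)n1`: 7%

Both measurements come from an assay for inhibition of MAP kinase-activated protein kinase 2 (Homo sapiens), tested at 1 uM; a higher number here means more inhibition at the concentration tested (going by the name of the read-out), a lower number less inhibition. For the measured compounds named here, compound 1 gives the highest of the two numbers, but the only other compound, compound 2, lies a number 6 percentage points lower from compound 1 to compound 2 (within the scatter), so no order between the two can be read from the data; the two values sit together within the scatter.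

The unmeasured compound 3, `COc1ccc(S(C)(=O)=O)cc1C(=O)Nc1cccc(-c2nncn2C(C)C)n1`, departs from compound 1 by a different kind of change: methyl in place of amino on a sulfonyl sulfur.

Going by the values given here, the one measured step, a number 6 percentage points lower from compound 1 to compound 2 (within the scatter), concerns a methyl in place of hydrogen on an aromatic carbon, a change elsewhere in the molecule. It does not touch the sulfonyl sulfur and so does not bear directly on the change from compound 1 to compound 3; it shows only that the one small alteration tried so far left the read-out within the scatter. Among the compounds with values here, there is no measured step that tells what methyl in place of amino on a sulfonyl sulfur does here.

With nothing pointing either way, the expected step is a number 3 percentage points lower from compound 1 to compound 3 (within the scatter), within the scatter. Compound 3 is therefore estimated at 10%, likely between 0% and 25%.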

Compound 3, a percentage reported as inhibition, at one concentration (the size of the read-out at that concentration, not a potency): 6%
The estimate for compound 3 lay 4 percentage points above the measured number, within the range that was stated.
By their numbers in this assay, from the lowest: compounds 3, 2 and 1 (each within the scatter of the next).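

Replacing the amino on the sulfonyl sulfur with methyl turns sulfamoyl into methylsulfonyl and gives a number 7 percentage points lower from compound 1 to compound 3 (within the scatter) in this assay, so this change cannot be told apart from no change at all. For the compounds shown here, the amino counts as a hydrogen-bond donor and the methyl does not, yet that difference in the count leaves no readable mark on the result, and the earlier compounds, which kept the sulfamoyl group intact, could not show this. Compound 1 itself gives only 13% at the concentration tested, which leaves little room for any loss to stand out, and no measurement is available that would explain the outcome at this position.

The compounds shown leave open whether a different group on the sulfonyl sulfur, such as dimethylamino, a longer chain like propyl or a cyclopropyl ring, would move the read-out clearly away from that of compound 1. They also leave open what a carboxylic acid or a nitrile would do in place of the whole sulfamoyl group.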